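Amide nitrogen substituent series: intrinsic activity notes

This account rests on a few compounds, and the source may have more. Where it says the series, first, only, none or still open, it means among the compounds named here.

Measured so far:
compound 1 `CCCNC(=O)C1=CC(C)(C)Oc2ccc([N+](=O)[O-])cc21` gives 74.1% in a functional assay on the whole organism (muscle tissue) with Rattus norvegicus as the target; on this read-out lower numbers stand for smaller maximal responses and higher numbers for larger maximal responses.
compound 2 `CC(C)NC(=O)C1=CC(C)(C)Oc2ccc([N+](=O)[O-])cc21` gives 77.6% in this assay.

Compound 2 stands highest of the two numbers in this assay, but its nearest neighbour is compound 1, and that gap, a number 3.5 percentage points higher from compound 1 to compound 2 (within the scatter), is within the scatter, so no order between the two can be claimed.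

Compound 3 `CC1(C)C=C(C(=O)NC2CC2)c2cc([N+](=O)[O-])ccc2O1` is not yet measured. It differs from compound 2 by cyclopropyl in place of isopropyl on an amide-type nitrogen. Within the data shown here, the only measured step that bears on this change is the one on the same amide-type nitrogen, a number 3.5 percentage points higher from compound 1 to compound 2 (within the scatter), which stayed within the scatter. On that basis no step beyond the scatter is expected for compound 3 in this assay, so a number 1.6 percentage points lower from compound 2 to compound 3 (within the scatter) is the estimated step.

Compound 3 is therefore estimated at 76% in this assay, with an expected range from 62% to 88%.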

Compound 3, intrinsic activity: the largest response reached, in percent of the reference agonist's: 78%
Compound 3: middle estimate off by 2 percentage points, on the low side; measured number inside the range.
By their numbers in this assay, from the lowest: compounds 1, 2 and 3 (each within the scatter of the next).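

On the amide-type nitrogen, cyclopropyl brings in a three-membered ring with the same number of heavy atoms as isopropyl, and in this assay the change from isopropyl gives a number 0.4 percentage points higher from compound 2 to compound 3 (within the scatter) while the change from propyl gives a number 3.9 percentage points higher from compound 1 to compound 3 (within the scatter) with neither step beyond the scatter. Propyl, isopropyl and cyclopropyl therefore stand within the scatter of one another at this position, so adding a ring shows no readable change and no order among the three can be claimed. Nothing on hand explains this flat result.

On these data alone, what a longer chain such as hexyl, a larger ring such as cyclohexyl or a chain ending in an amine would do on this nitrogen stays open. Also open, as far as these compounds go, is whether the same flat picture holds when the nitro group on the shared core gives way to a nitrile.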